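Piperazine nitrogen substituents on a shared triazine core

The source may report more compounds than this note shows. Statements on the series, on what has been measured and on what is new or still open speak of the compounds shown alone.

Measured compounds:
Compound 1 `N#Cc1ccc(Nc2nc(Oc3ccnc4ccccc34)nc(N3CCN(c4ccccc4Cl)CC3)n2)cc1C(F)(F)F`; in a functional assay on DU-145 cells (Homo sapiens) for cytotoxicity, read by sulforhodamine B assay, with a stated time of 48 h (a lower number here means that less compound is tolerated, a higher number that more compound is tolerated), compound 1 sits at the limit > 100000 nM.
Compound 2 `CC(=O)N1CCN(c2nc(Nc3ccc(C#N)c(C(F)(F)F)c3)nc(Oc3ccnc4ccccc34)n2)CC1`; in this assay compound 2 sits at the limit > 100000 nM.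
Compound 3 `CCN1CCN(c2nc(Nc3ccc(C#N)c(C(F)(F)F)c3)nc(Oc3ccnc4ccccc34)n2)CC1`; in this assay compound 3 sits at the limit > 100000 nM.

Compound 3 therefore has only a limit in this assay, and the two other values shown are limits as well, so no ranking among the three is possible. The steps between them are a step that the two limits leave unreadable from compound 1 to compound 2, a step that the two limits leave unreadable from compound 1 to compound 3 and a step that the two limits leave unreadable from compound 2 to compound 3; the reason is the limit of > 100000 nM in this assay, at which 3 of the 3 values shown sit.

Compound 4 `COc1ccc(N2CCN(c3nc(Nc4ccc(C#N)c(C(F)(F)F)c4)nc(Oc4ccnc5ccccc45)n3)CC2)cc1` differs from compound 3 as follows: 4-methoxyphenyl in place of ethyl on an amine nitrogen in a ring. Compound 1 already carries an aryl group on the same ring nitrogen and sits at the limit, so an aryl group at this position gives no sign of moving the value off the limit. The expected step that the limit leaves unreadable from compound 3 to compound 4 is therefore none beyond the scatter. Compound 4 is expected to give 150000 nM in this assay, within the range 50000 nM to 500000 nM, most likely again reported only as a limit.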

Compound 4, concentration lethal to 50% of the cells: > 100000 nM
Compound 4: only a limit was reported; the forecaster's own chance of this, stated with the estimate: 85%; the middle value lies beyond the limit too.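

No step to compound 4 from compound 1, compound 2 or compound 3 can be read in this assay, because every value is only a limit: the limit of > 100000 nM in this assay, at which 4 of the 4 values shown sit.

The compounds shown leave open how the four rank and whether any group on the ring nitrogen brings a value off this limit.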